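Three Measured Analogues and a Fourth Awaiting Its Number

This account rests on a few compounds, and the source may have more. Where it says the series, first, only, none or still open, it means among the compounds named here.

Compound 1, `N=C(N)NCCC[C@H](NC(=O)CN(c1nc(Cl)nc2[nH]cnc12)C1CC1)C(=O)O`, gives 12.1% in a functional assay on the whole organism (Tail, strain ICR) with Mus musculus as the target, in the tail flick test, with a stated time of 90 min, at a dose of 6.25 umol/kg by the oral route; on this read-out lower numbers stand for a weaker effect and higher numbers for a stronger effect at the one dose given.
Compound 2, `NCCCC[C@H](NC(=O)CN(c1nc(Cl)nc2[nH]cnc12)C1CC1)C(=O)OCc1ccccc1`, gives 11.3% in this assay.
Compound 3, `NCCCC[C@H](NC(=O)CN(c1nc(Cl)nc2[nH]cnc12)C1CC1)C(=O)O`, gives 14.5% in this assay.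

Within the data shown here, compound 3 has the highest of the three numbers, but the margins are small: the step of a number 2.4 percentage points higher from compound 1 to compound 3 (within the scatter) and the step of a number 3.2 percentage points higher from compound 2 to compound 3 (within the scatter) both lie within the scatter, so no compound can be called the strongest. The unmeasured compound 4, `CC(C)C[C@H](NC(=O)CN(c1nc(Cl)nc2[nH]cnc12)C1CC1)C(=O)O`, differs from compound 3 in one place: isopropyl in place of 3-aminopropyl on a saturated chain carbon, two bonds along the chain from an amide-type nitrogen and a carbonyl carbon. Neither measured step touches this position; one concerns the chain end four bonds along the chain, the other the oxygen next to the carbonyl group, and both were within the scatter. Among the measured compounds shown here, with no step bearing on the exchange, compound 4 is expected to stay close to compound 3, a step of a number 1.5 percentage points lower from compound 3 to compound 4 (within the scatter) that is not beyond the scatter. The estimate for compound 4 in this assay is 13%, with a range from 3% to 28%.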

Compound 4, a percentage reported as activity, at one dose (the size of the read-out at that dose, not a potency): 16.2%
Estimate against measurement, compound 4: 3.2 percentage points below, within the range that was stated.
By their numbers in this assay, from the lowest: compounds 2, 1, 3 and 4 (each within the scatter of the next).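

At the saturated chain carbon two bonds along the chain from an amide-type nitrogen and a carbonyl carbon, the exchange of 3-aminopropyl for isopropyl gives a number 1.7 percentage points higher from compound 3 to compound 4 (within the scatter) in this assay, with no nitrogen left in the group. Putting the same isopropyl in place of the side chain of compound 1 gives a number 4.1 percentage points higher from compound 1 to compound 4 (within the scatter), so at this one dose, a side chain with nitrogen and one of carbon alone cannot be told apart on this read-out. No measurement shown offers an explanation for this result.

The compounds shown leave open whether a carboxylic acid or a phenyl ring at this place would move the number beyond the scatter. They also leave open whether a benzyl ester of compound 4 would stay within the scatter of compound 4.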